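The source may report more compounds than this note shows. Statements on the series, on what has been measured and on what is new or still open speak of the compounds shown alone.

Working notes on the series in an ADME assay on Vero cells (Chlorocebus sabaeus) for cytotoxicity, read by luminescence, with a stated time of 2 days; a higher number here means that more compound is tolerated, a lower number that less compound is tolerated. Compound 1 `CCc1nc2ccccc2n1CCCCOc1ccc(Cl)c(F)c1` gives 16 uM, compound 2 `CCc1nc2ccc(C)cc2n1CCCCOc1ccccc1` gives 18 uM and compound 3 `CCc1nc2ccc(C)cc2n1CCCCNc1ccccc1` gives 21 uM. Compound 3 therefore stands level with the other two: its gaps to both lie within the scatter, so these numbers give no ordering.

Compound 4 `CCc1nc2ccc(C)cc2n1CCCCNc1ccc(C)c(Br)c1` carries 3-bromo-4-methylphenyl in place of phenyl on an amine nitrogen.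

For the measured compounds named here, one measured step bears on this part of the structure: a 1.2-fold higher number from compound 2 to compound 3 (0.07 log units; within the scatter). It exchanges phenoxy for anilino, adds nothing to the phenyl ring, and stays within the scatter. Going by the values given here, no measured step isolates substitution on that ring. Among the compounds with values here, compound 1, the only measured compound with substituents on its terminal ring, gives 16 uM, but it differs from compound 3 in more than one place, and the two values lie within the scatter of each other. In this assay, a slight fall is the most that can be expected, with nothing beyond the scatter. Within the data shown here, with no direct precedent for this group, the range stays wide.

The expected step is a 1.4-fold lower number from compound 3 to compound 4 (0.15 log units; within the scatter).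

For compound 4 the estimated value is 15 uM, with an expected range of 7 uM to 30 uM.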

Compound 4, half-maximal toxic concentration: 12 uM
Compound 4: middle estimate off by 1.3-fold (0.10 log units), on the high side, and the stated range covers the measured number.
By their numbers in this assay, from the lowest: compounds 4, 1, 2 and 3 (each within the scatter of the next).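

In this assay, for the compounds shown here, the exchange of phenyl for 3-bromo-4-methylphenyl on the amine nitrogen gives a 1.8-fold lower number from compound 3 to compound 4 (0.24 log units; within the scatter) and is the only measured step that isolates substitution on this terminal ring. This position therefore takes 3-bromo-4-methylphenyl with no separation from phenyl that these numbers can resolve, and the series still gives no firm ordering, with each of the four compounds within the scatter of the next. Nothing at hand connects the value of compound 4 to the bromine or to the methyl group, taken singly or together.

The compounds shown leave open whether 3-bromophenyl or 4-methylphenyl alone on the amine nitrogen would stay level with the parent phenyl of compound 3, so the two substituents cannot yet be read separately. They also leave open whether a more different group on this ring, such as a carboxylic acid or a dimethylamino group, would move the number beyond the scatter, and whether a shorter chain would do so.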